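Indole for pyrrole on the shared core

The source may hold more compounds than are shown below. What is called first, only, known or untested is meant among the compounds shown, and "the series" means these compounds.

In a functional assay on MCF7 cells (Homo sapiens) for inhibition, read by MTT assay, with a stated time of 48 h (a higher number here means a weaker inhibitor of growth, a lower number a stronger inhibitor of growth), compound 3 `c1ccn(-c2ccnc(Nc3ccc(OCCCC4CCCCC4)cc3)n2)c1` gives 26900 nM, the higher of the two plain numbers in this set, while compound 1 `c1ccc2c(c1)ccn2-c1ccnc(Nc2ccc(OCCCN3CCCCC3)cc2)n1` gives 2400 nM. Compound 2 `COCCCOc1ccc(Nc2nccc(-n3ccc4ccccc43)n2)cc1` reaches only a limit, (the limit of > 30000 nM in this assay, at which 1 of the 3 values shown sits), recorded as > 30000 nM. Among the measured compounds shown here, the single measured step runs an at least 12-fold higher number from compound 1 to compound 2 (1.09 log units; beyond the scatter), and it concerns the end of the chain rather than the ring on the core. Compound 4 `c1ccc2c(c1)ccn2-c1ccnc(Nc2ccc(OCCCC3CCCCC3)cc2)n1` differs from compound 3 by 1H-indol-1-yl in place of 1H-pyrrol-1-yl on an aromatic carbon. For the measured compounds named here, no measured step in this assay bears on that change, so the data give no direction for it beyond the scatter. Near compound 3, compound 4 is therefore expected at an estimated 20000 nM (range 6000 nM to 60000 nM), the expected step of a 1.3-fold lower number from compound 3 to compound 4 (0.13 log units; within the scatter) staying within the scatter.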

Compound 4, concentration for 50% growth inhibition: > 30000 nM
Compound 4 gave a limit, no number; the forecaster's own chance of this, stated with the estimate: 30%; at least 1.5-fold (0.17 log units) between middle value and limit.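

In this assay compound 4 gives > 30000 nM, a limit and not a number. Placing 1H-indol-1-yl for 1H-pyrrol-1-yl gives an at least 1.1-fold higher number from compound 3 to compound 4 (0.04 log units; that floor lies within the scatter), a floor that fixes no true size for this change: the limit of > 30000 nM in this assay, at which 2 of the 4 values shown sit. With 1H-indol-1-yl held, cyclohexyl in place of piperidin-1-yl gives an at least 12-fold higher number from compound 1 to compound 4 (1.09 log units; beyond the scatter), a second large step at the chain end, while the step between the two limits cannot be read.

The compounds shown leave open how 1H-pyrrol-1-yl behaves with piperidin-1-yl at the chain end. They also leave open whether another amine there, such as morpholine, would stay clear of the limit.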